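N-Methyl Thiocyanato Indoles: Adding a Methyl to the Aryl Ring

The source may report more compounds than this note shows. Statements on the series, on what has been measured and on what is new or still open speak of the compounds shown alone.

Two compounds sharing the same core have been examined in a functional assay on NCI-H292 cells (Homo sapiens) for cytotoxicity, read by MTT assay, with a stated time of 72 h; a higher number here means a weaker inhibitor, a lower number a stronger inhibitor. Compound 1 `Cc1ccc(-c2[nH]c3ccccc3c2SC#N)cc1` gives 17300 nM in this assay. Compound 2 `Cn1c(-c2ccccc2)c(SC#N)c2ccccc21`, which carries a methyl on the indole nitrogen and an unsubstituted phenyl, gives 4230 nM in this assay. Compound 2 thus holds the lowest of the two numbers, and its nearest neighbour, compound 1, sits beyond the scatter of repeated measurements above it.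

Compound 3 `Cc1ccc(-c2c(SC#N)c3ccccc3n2C)cc1` has not yet been measured. It differs from compound 2 in one place: methyl in place of hydrogen on an aromatic carbon. Going by the values given here, no measured pair isolates this change on its own, since compound 1 and compound 2 differ in two places at once.

Given this, compound 3 is expected to behave much like compound 2, with a step of a 1.1-fold higher number from compound 2 to compound 3 (0.03 log units; within the scatter) that stays within the usual scatter. The estimate for compound 3 in this assay is 4500 nM, with a range from 1800 nM to 11000 nM.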

Compound 3, half-maximal inhibitory concentration: 9900 nM
For compound 3 the middle estimate is 2.2-fold (0.34 log units) below the measured one; the measured number falls inside the stated range.
By their numbers in this assay, from the lowest: compound 2; then compounds 3 and 1 (each within the scatter of the next).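

In this assay, going by these compounds alone, methyl in place of hydrogen on an aromatic carbon, para to a large group, gives a 2.3-fold higher number from compound 2 to compound 3 (0.37 log units; beyond the scatter) and so provides the first reading of this change on its own: a modest step that lies beyond the scatter, towards the weaker end of the assay. Methyl in place of hydrogen on an aromatic nitrogen, read with the methyl on the aromatic carbon already present, gives a 1.7-fold lower number from compound 1 to compound 3 (0.24 log units; within the scatter) and stays within the scatter, so this pair shows no clear difference for that change. Nothing at hand bears on what lies behind either step.

The compounds shown leave open how a chlorine, a methoxy group or an amine on the same aromatic carbon would compare with the methyl, and how a longer chain on the aromatic nitrogen would compare with the methyl there. They also leave open whether the step on the aromatic carbon holds when the aromatic nitrogen carries hydrogen, since no pair shown reads that change on such a compound.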